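This account rests on a few compounds, and the source may have more. Where it says the series, first, only, none or still open, it means among the compounds named here.

Measured compounds:
Compound 1, `O=C(Nc1nnn[nH]1)c1coc(=O)c2ccccc12`. In a functional assay on cells (Mast cell, Rattus norvegicus) for inhibition, with a stated time of 15 min (a lower number here means that less compound is needed, a higher number that more compound is needed for the effect), compound 1 reports only a limit, > 18 ug/mL.
Compound 2, `O=C(O)CCCCCNC(=O)c1cc(=O)c2ccccc2o1`. In this assay compound 2 likewise reports only a limit, > 18 ug/mL.
Compound 3, `Cc1c(C(=O)Nc2nnn[nH]2)oc2ccccc2c1=O`. In this assay compound 3 gives 0.4 ug/mL.

For the measured compounds named here, compound 2 thus stands at the limit of this assay (the limit of > 18 ug/mL in this assay, at which 2 of the 3 values shown sit); no number is known for it, and no step between measured compounds can be drawn. Compound 4, `O=C(O)CCCNC(=O)c1cc(=O)c2ccccc2o1`, is not yet measured. It differs from compound 2 as carboxy in place of 2-carboxyethyl on a saturated chain carbon, three bonds along the chain from an amide-type nitrogen: a 2-carboxyethyl group leaves and a carboxy group enters on a saturated chain carbon, three bonds along the chain from an amide-type nitrogen. The acid and the amide are retained in both.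

With compound 2 at the limit, the step from compound 2 to compound 4 has no anchor; the expectation is for no change beyond the scatter in this assay, most likely another limit. The step from compound 2 to compound 4 is expected to be small, a step that the limit leaves unreadable from compound 2 to compound 4. For compound 4 the estimate in this assay is 25 ug/mL, in the range 10 ug/mL to 80 ug/mL.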

Compound 4, concentration for half-maximal effect: > 18 ug/mL
Compound 4: only a limit was reported (the forecaster's own chance of this, stated with the estimate: 70%); the middle value lies beyond the limit too.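

Compound 2 and compound 4 each report only a limit in this assay, so no step between them can be read: the limit of > 18 ug/mL in this assay, at which 3 of the 4 values shown sit.

The compounds shown leave open whether carboxy in place of 2-carboxyethyl changes the effect at all, and what number either compound would give.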